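The source may report more compounds than this note shows. Statements on the series, on what has been measured and on what is new or still open speak of the compounds shown alone.

Values measured in a physicochemical assay for solubility; a lower number here means a less soluble compound, a higher number a more soluble compound:
- compound 1 `COc1ccc(Cl)cc1C(=O)Nc1ccc([N+](=O)[O-])cc1Cl`: < 1 ug/mL (a limit)
- compound 2 `O=C(Nc1ccc([N+](=O)[O-])cc1Cl)c1cc(F)ccc1O`: 3.3 ug/mL
- compound 3 `COc1ccc(C(=O)Nc2ccc([N+](=O)[O-])cc2Cl)c(O)c1`: < 1 ug/mL (a limit)

For the measured compounds named here, compound 2 gives the only true number of the three, 3.3 ug/mL. The other two results are limits of the assay and not numbers, as this line shows: the limit of < 1 ug/mL in this assay, at which 2 of the 3 values shown sit.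

Compound 4 `Cc1ccc(O)c(C(=O)Nc2ccc([N+](=O)[O-])cc2Cl)c1` is compound 2 with a single swap, methyl in place of fluoro on an aromatic carbon. The change sits para to a hydroxy group.

Going by the values given here, no measured pair of compounds differs in one place, so the data give no direct guide to the size of this step. A small drop in this assay is expected, little beyond the usual scatter. That expectation leans to the low side because of the limit of < 1 ug/mL in this assay, at which 2 of the 3 values shown sit, and compound 4 may itself reach that limit.

The estimated change is a 1.7-fold lower number from compound 2 to compound 4 (0.22 log units; within the scatter).

For compound 4 the expected value is 2 ug/mL, with an estimated range of 0.8 ug/mL to 5 ug/mL.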

Compound 4, solubility: < 1 ug/mL
Compound 4 gave a limit, no number; the forecaster's own chance of this, stated with the estimate: 25%; at least 2.0-fold (0.30 log units) between middle value and limit.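

For the compounds shown here, this is the first measured step at this position: in this assay, methyl in place of fluoro, para to a hydroxy group, gives an at least 3.3-fold lower number from compound 2 to compound 4 (0.51 log units; beyond the scatter). Swapping one heavy atom for another, with no change in the count of hydrogen-bond donors or acceptors, is therefore enough to move this read-out beyond the usual scatter. The step gives only a minimum size, since compound 4 gives < 1 ug/mL, which is a limit of the assay and not a number, and most of the values now gather there: the limit of < 1 ug/mL in this assay, at which 3 of the 4 values shown sit.

Going by these compounds, how far compound 4 actually lies under that limit stays open, so the true step could be larger. Also open, on these data alone, is whether another group at this position, such as an amine or a carboxylic acid, would match or exceed the number of compound 2.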